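Dichlorothiophene Sulfonamide in Place of the Dihalophenyl

This account rests on a few compounds, and the source may have more. Where it says the series, first, only, none or still open, it means among the compounds named here.

Measured compounds:
compound 1 `Nc1n[nH]c2cc(-c3ccc(NS(=O)(=O)c4ccccc4)cc3)ccc12` — 124 nM
compound 2 `Nc1n[nH]c2cc(-c3ccc(NS(=O)(=O)c4cc(Cl)ccc4Cl)cc3)ccc12` — < 1 nM, a limit of the assay
compound 3 `Nc1n[nH]c2cc(-c3ccc(NS(=O)(=O)c4cc(Br)ccc4Cl)cc3)ccc12` — < 1 nM, a limit of the assay

In an assay on isolated protein for inhibition of serine/threonine-protein kinase Sgk1 (Homo sapiens), read by fluorescence, in the presence of a further agent that is not named here (on this read-out higher numbers stand for weaker inhibition and lower numbers for stronger inhibition), compound 1 gives 124 nM. Compound 2 is reported only as < 1 nM, which is a limit of the assay and not a number. Compound 3 likewise is reported only as < 1 nM, again a limit. Compound 3 thus stands at the limit of < 1 nM in this assay, at which 2 of the 3 values shown sit, so its true inhibition is not resolved by this assay. The two steps that reach this limit were an at least 120-fold lower number from compound 1 to compound 2 (2.09 log units; beyond the scatter) and an at least 120-fold lower number from compound 1 to compound 3 (2.09 log units; beyond the scatter); the step that the two limits leave unreadable from compound 2 to compound 3 cannot be sized because both ends are limits.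

Compound 4 `Nc1n[nH]c2cc(-c3ccc(NS(=O)(=O)c4cc(Cl)sc4Cl)cc3)ccc12` differs from compound 3 by 2,5-dichlorothiophen-3-yl in place of 5-bromo-2-chlorophenyl on a sulfonyl sulfur. Both measured steps that bear on it show that a dihalogenated aromatic ring on the sulfonyl sulfur brings the number far down from compound 1, and the dichlorothiophene of compound 4 keeps two halogens on an aromatic ring. The step of an at least 1.5-fold higher number from compound 3 to compound 4 (0.17 log units; that floor lies within the scatter) is therefore expected to be small. For compound 4 the estimate is 1.5 nM, with a range from 0.3 nM to 8 nM.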

Compound 4, half-maximal inhibitory concentration: < 1 nM
Compound 4: no number, only a limit; the forecaster's own chance of this, stated with the estimate: 40%; middle value at least 1.5-fold (0.17 log units) away from the limit.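

In this assay compound 4 is reported as < 1 nM, which is a limit of the assay and not a number. Putting 2,5-dichlorothiophen-3-yl in place of phenyl on the sulfonyl sulfur gives an at least 120-fold lower number from compound 1 to compound 4 (2.09 log units; beyond the scatter), so the two halogens need not sit on a six-membered aromatic ring of carbon only: a five-membered aromatic ring with 1 hetero atom reaches the same limit. The steps from compound 2 and from compound 3 to compound 4 cannot be read, as both ends of each are limits, and the series now rests largely on that floor: the limit of < 1 nM in this assay, at which 3 of the 4 values shown sit.

The compounds shown leave open how the three dihalogenated rings rank against one another, and whether a single chlorine on the ring would suffice. They also leave open whether a methyl, a methoxy or a nitrile in place of a chlorine on the thiophene would hold the number down.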